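The compounds below may be only part of what the source reports. "The series", "measured", "known", "first", "only" and "open" are said of these compounds alone.

The three measured compounds share one core and differ in the halogen on the benzamide and in the group carried by the amine nitrogen in a ring. Compound 1 `NC(=O)c1c(NC(=O)c2ccccc2Cl)sc2c1CCN(Cc1ccccc1Cl)C2` gives 4430 nM in a functional assay on MKN-74 cells (Homo sapiens) for antiproliferative activity, with a stated time of 24 h; a higher number here means a weaker inhibitor, a lower number a stronger inhibitor. Compound 2 `NC(=O)c1c(NC(=O)c2ccccc2Cl)sc2c1CCN(Cc1c(Cl)cccc1Cl)C2` gives 4740 nM in this assay. The step of a 1.1-fold higher number from compound 1 to compound 2 (0.03 log units; within the scatter) stays within the scatter. Compound 3 `NC(=O)c1c(NC(=O)c2ccccc2F)sc2c1CCN(Cc1cccc(Cl)c1)C2` gives 23300 nM in this assay, the highest number of the three and beyond the scatter from both compound 1 and compound 2, so it is the weakest inhibitor among them.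

Compound 4 `NC(=O)c1c(NC(=O)c2ccccc2F)sc2c1CCN(C(=O)Nc1ccccc1Cl)C2` differs from compound 3 by (2-chlorophenyl)carbamoyl in place of 3-chlorobenzyl on an amine nitrogen in a ring. Among the measured steps, only a 1.1-fold higher number from compound 1 to compound 2 (0.03 log units; within the scatter) exists, and it concerns an added chloro on an aromatic ring, not an exchange of a benzyl for a carbamoyl group on the amine nitrogen in a ring. Within the data shown here, no measured step therefore bears directly on this change, and the expectation rests only on the starting point of compound 3. The step of a 1.2-fold lower number from compound 3 to compound 4 (0.07 log units; within the scatter) is expected to be no larger than the scatter, with wide uncertainty in either direction. Compound 4 is estimated to give 20000 nM in this assay, within a range from 5000 nM to 80000 nM.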

Compound 4, half-maximal inhibitory concentration: 49600 nM
Estimate against measurement, compound 4: 2.5-fold (0.39 log units) below, within the range that was stated.
By their numbers in this assay, from the lowest: compounds 1 and 2 (each within the scatter of the next); then compound 3; then compound 4.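

Exchanging 3-chlorobenzyl for (2-chlorophenyl)carbamoyl on the amine nitrogen in a ring gives a 2.1-fold higher number from compound 3 to compound 4 (0.33 log units; beyond the scatter) in this assay, a modest loss of inhibition. Among these compounds, the one earlier step at this nitrogen's substituent, the added chloro on the aromatic ring of the benzyl group, gave a 1.1-fold higher number from compound 1 to compound 2 (0.03 log units; within the scatter), so this is the first single change there that moves the number beyond the scatter. The change is a composite one, since the entering group brings a carbonyl, a hydrogen-bond donor and a hydrogen-bond acceptor that the leaving group lacks and also carries its chlorine at a different ring position, and no measured evidence says which of these differences lies behind the step.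

A (3-chlorophenyl)carbamoyl group on the same nitrogen would separate the effect of the carbamoyl link from that of the chlorine's position, and a simple acetyl group would show whether the aromatic ring is needed at all. From the compounds shown here alone, it also remains open whether the same exchange would give a similar step with the 2-chlorobenzamide of compound 1 in place of the 2-fluorobenzamide of compound 3.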